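Trimethoxyphenyl in place of phenyl on compound 2

The source may report more compounds than this note shows. Statements on the series, on what has been measured and on what is new or still open speak of the compounds shown alone.

Three members of this series have numbers in a functional assay on M14 cells (Homo sapiens) for inhibition; on this read-out higher numbers stand for weaker inhibition of growth and lower numbers for stronger inhibition of growth. Compound 1 `O=C(/C=C/c1cccc(O)c1)c1cccc(-n2cc(-c3ccccc3)[nH]c2=O)c1` gives 4530 nM. Compound 2 `COc1cc(/C=C/C(=O)c2cccc(-n3cc(-c4ccccc4)[nH]c3=O)c2)cc(OC)c1OC` gives 1350 nM, the lowest of the three numbers, and its gaps to compound 1 and to compound 3 both lie beyond the usual scatter. Compound 3 `COc1ccc(-c2cn(-c3cccc(C(=O)/C=C/c4ccc(O)c(OC)c4)c3)c(=O)[nH]2)cc1` gives 5140 nM. No two of these compounds differ in a single place, so no clean step can be read from them; they show only that compound 2 stands apart from the other two.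

Compound 4 `COc1cc(/C=C/C(=O)c2cccc(-n3cc(-c4cc(OC)c(OC)c(OC)c4)[nH]c3=O)c2)cc(OC)c1OC` is not yet measured. It differs from compound 2 by 3,4,5-trimethoxyphenyl in place of phenyl on an aromatic carbon. Among the compounds with values here, nothing among the measured compounds isolates this change: compound 3 carries a methoxy-bearing ring on the same aromatic carbon but differs from compound 2 in a second place as well, so its value in this assay settles nothing here. The step is therefore expected to be small, toward a lower number, and it may fall within the scatter. For compound 4 the estimate in this assay is 1000 nM, with a range from 350 nM to 3000 nM. The expected step is a 1.4-fold lower number from compound 2 to compound 4 (0.13 log units; within the scatter).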

Compound 4, concentration for 50% growth inhibition: 2120 nM
Beside the measured number, compound 4's estimate is 2.1-fold (0.33 log units) below it, and the stated range covers the measured number.
By their numbers in this assay, from the lowest: compounds 2 and 4 (each within the scatter of the next); then compounds 1 and 3 (each within the scatter of the next).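

In this assay, within the data shown here, placing 3,4,5-trimethoxyphenyl in place of phenyl on the aromatic carbon of the five-membered aromatic ring with 2 nitrogen gives a 1.6-fold higher number from compound 2 to compound 4 (0.20 log units; within the scatter), and this is the first step that isolates this position. On this read-out the two groups cannot be told apart, so the heavier aromatic group and the hydrogen-bond acceptors that enter with it bring no change beyond the scatter, at least with the trimethoxyphenyl-bearing enone side of compound 2 held fixed. Nothing measured alongside this result offers an explanation for it.

Whether this position stays as undemanding for a group of another kind remains open, since the compounds shown carry only phenyl and methoxy-bearing aromatic rings there and include nothing such as a carboxylic acid, a dimethylamino group or a longer alkyl chain. Also open, as far as these compounds go, is whether the same exchange gives a similar outcome when the aromatic ring on the other end of the core differs, as it does in compound 1 and compound 3, neither of which has a partner differing from it in one place.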